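The source may report more compounds than this note shows. Statements on the series, on what has been measured and on what is new or still open speak of the compounds shown alone.

Three measured compounds share one core and differ only in the ring carried on the carbonyl carbon. Compound 1 `COc1ccc(C#Cc2ccc(C(=O)N3CCC(CO)C3)cc2)cc1` reached only the limit of a functional assay on HEK293 cells for negative allosteric modulation of metabotropic glutamate receptor 2 (Rattus norvegicus), read by calcium flux, with a stated time of 2.5 min (a lower number here means a stronger inhibitor, a higher number a weaker inhibitor), giving > 30000 nM. Compound 2 `COc1ccc(C#Cc2ccc(C(=O)N3CC4CCC(O)C4C3)cc2)cc1` likewise gave only the limit > 30000 nM in this assay. Compound 3 `COc1ccc(C#Cc2ccc(C(=O)N3CCCC(C)(O)C3)cc2)cc1` stands at the limit as well, with > 30000 nM in this assay, so no number places it relative to the others. Among the measured compounds shown here, the steps a step that the two limits leave unreadable from compound 1 to compound 3 and a step that the two limits leave unreadable from compound 2 to compound 3 are therefore unreadable, and the limit of > 30000 nM in this assay, at which 3 of the 3 values shown sit, describes every value so far. Compound 4 `COc1ccc(C#Cc2ccc(C(=O)N3CC[C@H](O)C3)cc2)cc1` differs from compound 3 by 3-hydroxypyrrolidin-1-yl in place of 3-hydroxy-3-methylpiperidin-1-yl on a carbonyl carbon. With no readable step, no direction beyond the scatter can be expected. Compound 4 is estimated at 40000 nM, within a range of 15000 nM to 150000 nM. The expected step that the limit leaves unreadable from compound 3 to compound 4 is accordingly estimated to be small.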

Compound 4, half-maximal inhibitory concentration: > 30000 nM
Compound 4 gave a limit, no number (the forecaster's own chance of this, stated with the estimate: 85%); the middle value does not contradict the limit.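

Compound 4 also gives only a limit, so no step from compound 1, compound 2 or compound 3 to compound 4 can be read: the limit of > 30000 nM in this assay, at which 4 of the 4 values shown sit.

The compounds shown leave open whether the ring on the carbonyl carbon affects inhibition at all.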